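Nitro to Methoxy: What to Expect of Compound 4

This account rests on a few compounds, and the source may have more. Where it says the series, first, only, none or still open, it means among the compounds named here.

Compound 1, `COc1cc(OC)c(OC)cc1/C=C/C(=O)c1ccc(O)cc1`, in a functional assay on MCF7 cells (Homo sapiens) for inhibition, read by MTT assay, with a stated time of 72 h (a higher number here means a weaker inhibitor, a lower number a stronger inhibitor), gives 182000 nM.
Compound 2, `COc1cc(OC)c(OC)cc1/C=C/C(=O)c1ccc(O)cc1O`, in this assay gives 33800 nM.
Compound 3, `COc1cc(OC)c(OC)cc1/C=C/C(=O)c1ccc([N+](=O)[O-])cc1`, in this assay gives > 150000 nM, which is a limit of the assay and not a number.

Compound 3 therefore stands only at the limit of > 150000 nM in this assay, at which 1 of the 3 values shown sits, and its true potency is not read. Among the measured steps, the only readable one is a 5.4-fold lower number from compound 1 to compound 2 (0.73 log units; beyond the scatter). The other, a step that the limit leaves unreadable from compound 1 to compound 3, cannot be sized.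

Compound 4, `COc1ccc(C(=O)/C=C/c2cc(OC)c(OC)cc2OC)cc1`, differs from compound 3 by methoxy in place of nitro on an aromatic carbon. Among the measured compounds shown here, no measured step exchanges nitro for methoxy, so the step is weighed against compound 1, which carries hydroxy at the same aromatic carbon and gives 182000 nM, a weak value itself. Compound 4 is expected to land near that weak region, with a fair chance that it too reaches only a limit. The estimate for compound 4 is 160000 nM, within 50000 nM to 450000 nM, meaning an expected step that the limit leaves unreadable from compound 3 to compound 4.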

Compound 4, half-maximal inhibitory concentration: 33900 nM
Beside the measured number, compound 4's estimate is 4.7-fold (0.67 log units) above it; the measured number lies below the stated range.
By their numbers in this assay, from the lowest: compounds 2 and 4 (each within the scatter of the next); then compound 1.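

At this aromatic carbon, para to a large group, the hydroxy hydrogen turns out not to be required: methyl in place of that hydrogen gives a 5.4-fold lower number from compound 1 to compound 4 (0.73 log units; beyond the scatter) in this assay, and exchanging the whole 2,4-dihydroxyphenyl for 4-methoxyphenyl gives a 1.0-fold higher number from compound 2 to compound 4 (0.00 log units; within the scatter). Methoxy in place of nitro gives an at least 4.4-fold lower number from compound 3 to compound 4 (0.64 log units; beyond the scatter), so the exchange now has a readable lower bound on its size. Compound 3 itself remains a limit and not a number: the limit of > 150000 nM in this assay, at which 1 of the 4 values shown sits.

As far as these compounds go, the true size of the nitro to methoxy step therefore stays open. So does the question of whether an amine, a carboxylic acid or a longer alkoxy chain such as ethoxy at this aromatic carbon would hold the level reached by the methoxy or move away from it.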